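Chloro for methoxy: from compound 1 toward compound 4

This account rests on a few compounds, and the source may have more. Where it says the series, first, only, none or still open, it means among the compounds named here.

Compound 1 `COc1ccc(-c2nn(-c3ccccc3)cc2/C=C/C(=O)c2ccc(O)c3c2OC(C)(C)C3)cc1` carries a methoxy-bearing aryl ring on the shared core. In a functional assay on PC-3 cells (Homo sapiens) for antiproliferative activity, read by MTT assay, with a stated time of 48 h (on this read-out lower numbers stand for stronger inhibition and higher numbers for weaker inhibition), compound 1 gives 20800 nM, the highest of the two plain numbers recorded so far; its nearest neighbour is compound 2 `COc1ccc(-c2nn(-c3ccccc3)cc2/C=C/C(=O)c2ccc(OCc3ccccc3)c3c2OC(C)(C)C3)cc1`, which in this assay gives 7900 nM. For the measured compounds named here, the only measured single-place step is a 2.6-fold lower number from compound 1 to compound 2 (0.42 log units; beyond the scatter), and it concerns the oxygen on the core, not the aryl ring. Compound 3 `CC1(C)Cc2c(OCc3ccccc3)ccc(C(=O)/C=C/c3ccc(Cl)cc3Cl)c2O1` reaches only the limit of this assay: compound 3 gives > 100000 nM, a limit rather than a number, (the limit of > 100000 nM in this assay, at which 1 of the 3 values shown sits). Going by the values given here, compound 3 differs from compound 2 in more than one place, so no step between them is drawn.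

Compound 4 `CC1(C)Cc2c(O)ccc(C(=O)/C=C/c3cn(-c4ccccc4)nc3-c3ccc(Cl)cc3)c2O1` is compound 1 with chloro in place of methoxy on an aromatic carbon. Among the compounds with values here, no measured step touches this site: the step from compound 1 to compound 2 sits elsewhere, and compound 3, though it carries chloro groups, differs from the other compounds at several places at once. With nothing to point either way, no step beyond the scatter is expected in this assay, in either direction. The expected step is a 1.2-fold higher number from compound 1 to compound 4 (0.08 log units; within the scatter). Compound 4 is therefore estimated at 25000 nM, with a range from 8000 nM to 80000 nM.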

Compound 4, half-maximal inhibitory concentration: 18000 nM
The estimate for compound 4 lay 1.4-fold (0.14 log units) above the measured number; the measured number falls inside the stated range.
By their numbers in this assay, from the lowest: compound 2; then compounds 4 and 1 (each within the scatter of the next). At a limit, above all of these: compound 3.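

In this assay, for the compounds shown here, the change from 4-methoxyphenyl to 4-chlorophenyl gives a 1.2-fold lower number from compound 1 to compound 4 (0.06 log units; within the scatter), the first measured step at this aromatic carbon, para to a large group. At this site, with the hydrogen kept on the core oxygen, a swap that removes one heavy atom and the one hydrogen-bond acceptor of the methoxy leaves the read-out within the scatter, whereas a 2.6-fold lower number from compound 1 to compound 2 (0.42 log units; beyond the scatter), at the core oxygen, remains the only step shown that lies beyond it. Nothing measured for these compounds bears on why this step is so small.

Going by these compounds, whether this site stays as flat with other groups remains open: an amine, a carboxylic acid or a longer alkoxy chain on the same aromatic carbon could still move the number beyond the scatter. Also open is whether chloro in place of methoxy gives a step of similar size when benzyl sits on the core oxygen, as it does in compound 2, since the two changes have not been seen together in one compound shown here.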